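Side-chain swap on the shared core: cytotoxicity notes

The source may report more compounds than this note shows. Statements on the series, on what has been measured and on what is new or still open speak of the compounds shown alone.

Compound 1 `COc1ccc(/C=C\c2cc(OC)c(OC)c(OC)c2)cc1OCc1ccc(CN[C@H](C(=O)O)[C@H](C)O)cc1` has been tested in an ADME assay on NCM460 cells (Homo sapiens) for cytotoxicity, read by CCK-8 assay, with a stated time of 48 h; a higher number here means a weaker inhibitor, a lower number a stronger inhibitor. Compound 1 gives > 50000 nM, which is a limit of the assay and not a number. Compound 2 `COc1ccc(/C=C\c2cc(OC)c(OC)c(OC)c2)cc1OCc1ccc(CN[C@H](C(=O)O)[C@@H](C)O)cc1` has the same atoms and bonds and differs only in configuration as drawn. In this assay compound 2 gives > 50000 nM, again a limit. The step that the two limits leave unreadable from compound 1 to compound 2 is therefore unreadable, as the limit of > 50000 nM in this assay, at which 2 of the 2 values shown sit, and the fact that compounds 1 and 2 differ only in the configuration as drawn show. Compound 3 `COc1ccc(/C=C\c2cc(OC)c(OC)c(OC)c2)cc1OCc1ccc(CNCCN(C)C)cc1` is not yet measured in this assay; it carries 2-(dimethylamino)ethyl in place of 1-carboxy-2-hydroxypropyl on an amine nitrogen. Among the measured compounds shown here, no measured step bears on this change: the only step known concerns configuration alone and cannot be sized. With compound 1 standing only at a limit, the step of an at least 1.2-fold lower number from compound 1 to compound 3 (0.09 log units; that floor lies within the scatter) is expected to be small or itself unreadable. Compound 3 is expected to give 40000 nM, in the range 10000 nM to 100000 nM, quite possibly reported once more as a limit.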

Compound 3, half-maximal inhibitory concentration: 35000 nM
Compound 3: middle estimate off by 1.1-fold (0.06 log units), on the high side; measured number inside the range.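

Replacing 1-carboxy-2-hydroxypropyl with 2-(dimethylamino)ethyl on an amine nitrogen gives an at least 1.4-fold lower number from compound 1 to compound 3 (0.15 log units; that floor lies within the scatter), and the same change gives an at least 1.4-fold lower number from compound 2 to compound 3 (0.15 log units; that floor lies within the scatter). Among the compounds shown here, compound 3 is the first compound with a numerical reading rather than a limit in this assay, so this position now has a step with a stated floor, which the configurational pair could not provide. Even so, the full size of the change stays unknown because of the limit: the limit of > 50000 nM in this assay, at which 2 of the 3 values shown sit.

As far as these compounds go, it remains open how a longer chain ending in dimethylamino, or a primary amine, would read on this nitrogen. From the compounds shown here alone, it is also open whether the carboxylic acid or the hydroxyl of 1-carboxy-2-hydroxypropyl accounts for any of the difference.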